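This account rests on a few compounds, and the source may have more. Where it says the series, first, only, none or still open, it means among the compounds named here.

Compound 1 `CC(=O)c1ccc2c(c1)C(n1ccccc1=O)=CC(C)(C)O2` is the compound from which this account proceeds. In a functional assay (trachea) with Rattus norvegicus as the target (a lower number here means a less potent compound, a higher number a more potent compound, by a factor of ten per unit of this negative logarithm), compound 1 gives 6.65. It stands highest of the three measured compounds in this assay. Compound 3 `CC1(C)C=C(n2ccccc2=O)c2cc(OC(=O)Nc3ccccc3)ccc2O1` lies nearest, and in this assay compound 3 gives 4.89, a number beyond the scatter below compound 1. Compound 2 `CC1(C)C=C(n2ccccc2=O)c2cc(OCC(=O)c3ccc(F)cc3)ccc2O1` lies furthest, and in this assay compound 2 gives 4.77, also beyond the scatter below compound 1.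

Compound 4 `CC1(C)C=C(n2ccccc2=O)c2cc(C#N)ccc2O1` has not yet been measured. It differs from compound 1 by cyano in place of acetyl on an aromatic carbon.

Among the measured compounds shown here, the only measured step between compounds differing in one place is a number 0.12 log units higher from compound 2 to compound 3 (within the scatter), a swap of phenylcarbamoyl for ((4-fluorophenyl)carbonyl)methyl on an oxygen on an aromatic ring. That step sits at another place and exchanges other groups, so it does not bear on the change from acetyl to cyano. For the measured compounds named here, no measured step therefore speaks directly to compound 4; what the data show is only that compound 1, with its acetyl, stands highest, and that the two compounds carrying bulkier groups sit well below it. Since cyano is, like acetyl, a small group with one hydrogen-bond acceptor, a step of a number 0.35 log units lower from compound 1 to compound 4 (beyond the scatter) is expected, within or near the scatter, leaning downward. Compound 4 is estimated at 6.3, in a range from 5.5 to 7.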

Compound 4, logarithm of the reciprocal of the active concentration, log(1/C): 7.1
For compound 4 the middle estimate is 0.80 log units below the measured one; the whole stated range lies below it.
By their numbers in this assay, from the lowest: compounds 2 and 3 (each within the scatter of the next); then compound 1; then compound 4.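

In this assay the step of a number 0.45 log units higher from compound 1 to compound 4 (beyond the scatter) shows that acetyl is not needed for the high number at this aromatic carbon, meta to a fused ring and para to a fused ring. Cyano, with 2 heavy atoms against the 3 of acetyl, keeps the count of 1 hydrogen-bond acceptor and 0 hydrogen-bond donors, and the number still rises, modestly but beyond the scatter, so this place accepts a change in the group's size and bond type without any loss in this assay. Nothing at hand accounts for the gain, and the measured change cannot be assigned to any one difference between the two groups.

The compounds shown compare only acetyl and cyano directly at this carbon, so it remains open how an amine, a carboxylic acid, a methyl ester or a longer chain such as propyl would fare there. As far as these compounds go, it is also open whether the modest gain would hold with a different group on the rest of the core, or whether it is confined to the pairing with the core of compound 1.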